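Chain length and an aryl swap in a quinazoline series

The compounds below may be only part of what the source reports. "The series", "measured", "known", "first", "only" and "open" are said of these compounds alone.

Measured compounds:
compound 1, `C#Cc1cccc(Nc2ncnc3cc(OCCCCn4ccnc4[N+](=O)[O-])c(OC)cc23)c1`, 2210 nM
compound 2, `C#Cc1cccc(Nc2ncnc3cc(OCCCCCn4ccnc4[N+](=O)[O-])c(OC)cc23)c1`, 770 nM
compound 3, `COc1cc2c(Nc3cccc(Br)c3)ncnc2cc1OCCCCCn1ccnc1[N+](=O)[O-]`, 8780 nM

All three were tested in a functional assay on A549 cells (Homo sapiens) for inhibition, read by sulforhodamine B assay, with a stated time of 72 h (on this read-out higher numbers stand for weaker inhibition and lower numbers for stronger inhibition), so a smaller number means the cells were harder to keep growing. Compound 1 gives 2210 nM. Compound 2 gives 770 nM. The difference between them is one change, ((2-nitro-1H-imidazol-1-yl)methyl in place of 2-nitro-1H-imidazol-1-yl on a saturated chain carbon, four bonds along the chain from an oxygen on an aromatic ring), and it made a 2.9-fold lower number from compound 1 to compound 2 (0.46 log units; beyond the scatter). Compound 3 gives 8780 nM, the highest of the three numbers; the change from compound 2 to compound 3 is bromo in place of ethynyl on an aromatic carbon, and it made an 11-fold higher number from compound 2 to compound 3 (1.06 log units; beyond the scatter). How the core of compound 3 differs from that of compound 1 is not broken down here.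

Compound 4, `COc1cc2c(Nc3cccc(Br)c3)ncnc2cc1OCCCCCCn1ccnc1[N+](=O)[O-]`, has not yet been measured. It stands to compound 3 as compound 2 stands to compound 1: the change is (2-nitro-1H-imidazol-1-yl)methyl in place of 2-nitro-1H-imidazol-1-yl on a saturated chain carbon, five bonds along the chain from an oxygen on an aromatic ring. This is the same kind of change, not the same, since the place differs: the change sits four bonds along the chain from the aromatic oxygen in compound 1, but five bonds along in compound 3. Going by the values given here, the only guide is that lengthening the chain in compound 1 gave a 2.9-fold lower number from compound 1 to compound 2 (0.46 log units; beyond the scatter), so a step of similar direction, and perhaps smaller size, is expected from compound 3 to compound 4, namely a 2.5-fold lower number from compound 3 to compound 4 (0.40 log units; beyond the scatter). On that basis compound 4 is estimated at 3500 nM, with the likely range running from 1500 nM to 9000 nM.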

Compound 4, half-maximal inhibitory concentration: 30200 nM
Compound 4: middle estimate off by 8.6-fold (0.94 log units), on the low side, outside the stated range (above it).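

In this assay, adding one carbon to the chain lowered the number on the ethynyl core but raised it on the bromo core, giving a 3.4-fold higher number from compound 3 to compound 4 (0.54 log units; beyond the scatter). The same structural change therefore cannot be assumed to carry over from one core to the other in this series, as the two steps run in opposite directions and differ by more than the scatter: the same change on two cores in this assay, a 2.9-fold lower number (0.46 log units; beyond the scatter) from compound 1 to compound 2 and a 3.4-fold higher number (0.54 log units; beyond the scatter) from compound 3 to compound 4, 9.9-fold (0.99 log units) apart, beyond the scatter of two such steps What this does not show is which difference between the two steps matters, since they differ both in the aromatic group, ethynyl or bromo, and in the place of the change, four or five bonds along the chain from the aromatic oxygen, and the data give no reason for the reversal.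

The compounds shown leave open whether the ethynyl core would also turn worse with the six-carbon chain of compound 4, and whether the bromo core would improve on going from the four-carbon chain of compound 1 to the five-carbon chain of compound 3, two pairings that would separate the aromatic group from the chain length. They also leave open how either core behaves with a still longer chain, or with a chloro group in place of bromo.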